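This account rests on a few compounds, and the source may have more. Where it says the series, first, only, none or still open, it means among the compounds named here.

Compound 1 `COc1ccc(/C=C/C(=O)OCC(=O)Nc2ccccc2)cc1OC` gives > 200000 nM in a functional assay on PC-3 cells (Homo sapiens) for cytotoxicity, read by MTT assay, with a stated time of 72 h (a higher number here means a weaker inhibitor, a lower number a stronger inhibitor), a limit of the assay and not a measured number.
Compound 2 `COCOc1cc(/C=C/C(=O)OCC(=O)NCc2ccco2)ccc1OCc1ccccc1` gives > 200000 nM in this assay, again a limit.
Compound 3 `COc1ccc(/C=C/C(=O)OCC(=O)Nc2ccc(Cl)cc2)cc1OC` gives > 200000 nM in this assay, again a limit.

All three values sit at the limit of > 200000 nM in this assay, at which 3 of the 3 values shown sit, so compound 2 stands where every measured compound stands: no number is known for it, only a limit, and nothing can be said about its order relative to compound 1 or compound 3. Within the data shown here, the only measured step, a step that the two limits leave unreadable from compound 1 to compound 3, joins two limits and its size cannot be read.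

Compound 4 `COCOc1cc(/C=C/C(=O)OCC(=O)Nc2ccc(OC)cc2)ccc1OCc1ccccc1` arises from compound 2 by 4-methoxyphenyl in place of (furan-2-yl)methyl on an amide-type nitrogen. Among the measured compounds shown here, no measured step touches the amide-type nitrogen in this way, and the one step that exists carries no readable size, so there is no evidence for a shift in this assay in either direction. The expectation is therefore that compound 4 stays at the limit, giving an expected step of a number no higher from compound 2 to compound 4 (the limit leaves the size open). Compound 4 is estimated at 200000 nM, with a range from 100000 nM to 400000 nM.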

Compound 4, half-maximal inhibitory concentration: > 200000 nM
Compound 4 gave a limit, no number (the forecaster's own chance of this, stated with the estimate: 85%); the middle value lies on the limit itself.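

The step from compound 2 to compound 4 cannot be read, since both compounds give only a limit of the assay and not a number. The compounds shown leave open how strong any of them is and whether any change among them alters activity, with every value at one limit: the limit of > 200000 nM in this assay, at which 4 of the 4 values shown sit.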